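Working notes on the ring-nitrogen substituent of the dithiocarbamate series

The source may hold more compounds than are shown below. What is called first, only, known or untested is meant among the compounds shown, and "the series" means these compounds.

Three compounds share one core and differ only in the group on the ring nitrogen. In a functional assay on MGC-803 cells (Homo sapiens) for antiproliferative activity, read by CCK-8 assay, with a stated time of 72 h, tested at 8 uM (on this read-out lower numbers stand for a weaker effect and higher numbers for a stronger effect at the one concentration tested), compound 1 `Nc1ccccc1NC(=O)c1ccc(CSC(=S)N2CCN(c3ccc(Cl)cc3)CC2)cc1` gives 17.2%, compound 2 `Nc1ccccc1NC(=O)c1ccc(CSC(=S)N2CCN(c3ccc(F)cc3)CC2)cc1` gives 48.7%, and compound 3 `Nc1ccccc1NC(=O)c1ccc(CSC(=S)N2CCN(c3ncccn3)CC2)cc1` gives 64.8%. Compound 3 stands highest of the three: the steps of a number 47.6 percentage points higher from compound 1 to compound 3 (beyond the scatter) and a number 16.1 percentage points higher from compound 2 to compound 3 (beyond the scatter) both lie beyond the scatter, as does a number 31.5 percentage points higher from compound 1 to compound 2 (beyond the scatter).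

Compound 4 `Nc1ccccc1NC(=O)c1ccc(CSC(=S)N2CCN(Cc3cccnc3)CC2)cc1` is not yet measured. It differs from compound 3 in one place: (pyridin-3-yl)methyl in place of pyrimidin-2-yl on an amine nitrogen in a ring. All three measured steps concern this same ring nitrogen, and the two that end at compound 3 carry a rise into pyrimidin-2-yl. Going by the values given here, none of them exchanges an aromatic group directly on the nitrogen for a (pyridin-3-yl)methyl group, so no measured step mirrors this change. The expectation for compound 4 in this assay is therefore a step of a number 14.8 percentage points lower from compound 3 to compound 4 (beyond the scatter), a modest fall that may well stay within the scatter. Compound 4 is estimated at 50%, within 25% to 75%.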

Compound 4, a percentage reported as inhibition, at one concentration (the size of the read-out at that concentration, not a potency): 64.6%
Beside the measured number, compound 4's estimate is 14.6 percentage points below it, and the stated range covers the measured number.
By their numbers in this assay, from the lowest: compound 1; then compound 2; then compounds 4 and 3 (each within the scatter of the next).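

In this assay, the ring nitrogen accepts a (pyridin-3-yl)methyl group as well as a pyrimidin-2-yl group, with a number 0.2 percentage points lower from compound 3 to compound 4 (within the scatter), so an aromatic ring placed directly on that nitrogen is not required for a number at this level. The same group also stands clear of both halogenated phenyl groups, with a number 15.9 percentage points higher from compound 2 to compound 4 (beyond the scatter) and a number 47.4 percentage points higher from compound 1 to compound 4 (beyond the scatter), which leaves the 4-fluorophenyl and 4-chlorophenyl compounds as the two low members of the set. Nothing measured on these compounds accounts for these steps.

Open, as far as these compounds go, is whether the pyridine ring or its one-carbon link matters more at this position, a question a benzyl group or a longer chain ending in the same ring would address. A plain methyl group on the nitrogen would show what an aromatic ring adds at all.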